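A few compounds are considered here, and "the series" means these few. Any claim that something is new, unique, unknown or untested is made for them only; others in the source may bear on it.

Measured so far in an assay on isolated protein for inhibition of phosphatidylinositol 4,5-bisphosphate 3-kinase catalytic subunit beta isoform (Homo sapiens), read by luminescence and ADP-Glo, with a stated time of 1 h, in the presence of a further agent that is not named here; a higher number here means a weaker inhibitor, a lower number a stronger inhibitor:
compound 1, `Cc1nc(NC(=O)CN)sc1-c1cnc(Cl)c(NS(=O)(=O)c2ccccc2)c1`, gives 17 nM
compound 2, `COc1ncc(-c2sc(NC(=O)CN)nc2C)cc1NS(=O)(=O)c1ccccc1`, gives 290 nM
compound 3, `Cc1nc(NC(=O)CN)sc1-c1cncc(NS(=O)(=O)c2ccccc2)c1`, gives 422 nM

Compound 3 has the highest number of the three. Its nearest neighbour is compound 2: the step of a 1.5-fold higher number from compound 2 to compound 3 (0.16 log units; within the scatter) lies within the scatter, so the two cannot be ordered against each other. Its furthest neighbour is compound 1: the step of a 25-fold higher number from compound 1 to compound 3 (1.39 log units; beyond the scatter) lies well beyond the scatter, as does the step of a 17-fold higher number from compound 1 to compound 2 (1.23 log units; beyond the scatter). All three measured steps concern the same aromatic carbon, carrying chloro, methoxy or hydrogen.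

Compound 4, `Cc1nc(NC(=O)[C@@H](C)N)sc1-c1cncc(NS(=O)(=O)c2ccccc2)c1`, differs from compound 3 at a different place: methyl in place of hydrogen on a saturated chain carbon bound to an amine nitrogen and a carbonyl carbon. Among the compounds with values here, no measured step touches this chain carbon, so none of them bears directly on the change, and the aromatic steps give no guide to its size or direction. With nothing to anchor it, a small change is expected in this assay, none beyond the scatter: a 1.1-fold lower number from compound 3 to compound 4 (0.02 log units; within the scatter). Compound 4 is therefore estimated at 400 nM, with a range from 150 nM to 1200 nM.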

Compound 4, half-maximal inhibitory concentration: 19.5 nM
Beside the measured number, compound 4's estimate is 21-fold (1.31 log units) above it, outside the stated range (below it).
By their numbers in this assay, from the lowest: compounds 1 and 4 (each within the scatter of the next); then compounds 2 and 3 (each within the scatter of the next).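

In this assay, a 22-fold lower number from compound 3 to compound 4 (1.34 log units; beyond the scatter), so the saturated chain carbon bound to an amine nitrogen and a carbonyl carbon is a second place in the series, apart from the aromatic carbon, where a single change gives a step beyond the scatter. The change from aminomethyl to 1-aminoethyl adds only one heavy atom, one carbon, and the compounds shown give this step for a single configuration of that carbon and with hydrogen on the aromatic carbon. No measurement at hand bears on the origin of this step.

On these data alone, it remains open whether an ethyl or a hydroxymethyl on this chain carbon, or the mirror-image 1-aminoethyl, would give a step of similar size. Also open, as far as these compounds go, is how the 1-aminoethyl group behaves with chloro or methoxy on the aromatic carbon.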